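This account rests on a few compounds, and the source may have more. Where it says the series, first, only, none or still open, it means among the compounds named here.

Compound 2 `COC[C@H]1C[C@@](CC(C)C)(C(=O)O)N(C(=O)c2ccc(C(C)(C)C)c(OC)c2)[C@H]1C(=O)OC` has been tested in an ADME assay on Huh-5-2 cells (Homo sapiens) for cytotoxicity, with a stated time of 3 days (on this read-out higher numbers stand for lower toxicity in this test and lower numbers for higher toxicity in this test), only up to a limit, and compound 2 reaches > 120000 nM there, which is a limit of the measurement rather than a number. Compound 1 `CCOC(=O)c1csc([C@H]2[C@@H](COC)C[C@@](CC(C)C)(C(=O)O)N2C(=O)c2ccc(C(C)(C)C)c(OC)c2)n1` gives 200000 nM in this assay, so the step that the limit leaves unreadable from compound 1 to compound 2 cannot be read because of the limit of > 120000 nM in this assay, at which 1 of the 2 values shown sits. Compound 3 `CC[C@H]1[C@@H](COC)C[C@@](CC(C)C)(C(=O)O)N1C(=O)c1ccc(C(C)(C)C)c(OC)c1` differs from compound 2 in one place: ethyl in place of methoxycarbonyl on a saturated ring carbon. Within the data shown here, only this unreadable step bears on the change, so no firm size follows from it. Compound 3 is therefore expected near 150000 nM, with a range from 50000 nM to 300000 nM, which means an expected step that the limit leaves unreadable from compound 2 to compound 3.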

Compound 3, half-maximal cytotoxic concentration: 200000 nM
Compound 3: the middle estimate sits 1.3-fold (0.12 log units) below what was measured; low and high end bracket the measured number.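

Among these compounds, this gives the first readable comparison at this saturated ring carbon, next to the ring nitrogen. In this assay, ethyl and 4-(ethoxycarbonyl)-1,3-thiazol-2-yl on this carbon give the same reading, with no change at the digits printed from compound 1 to compound 3 (within the scatter), so replacing that ring-bearing group with a ring-free chain leaves this read-out in place. Compound 2 has only a limit, not a number, so both steps that involve it cannot be read: the limit of > 120000 nM in this assay, at which 1 of the 3 values shown sits.

On these data alone, whether an amine or a carboxylic acid on this carbon would move the reading remains open. The same holds for a longer chain such as butyl.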